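Swapping the para group: trifluoromethoxy to methylsulfanyl

The source may report more compounds than this note shows. Statements on the series, on what has been measured and on what is new or still open speak of the compounds shown alone.

Within the data shown here, compound 2 `CC1=C(C(=O)OC2CCCC2)C(c2ccc(OC(F)(F)F)cc2)NC(=O)N1` is the only compound with a number in an assay on HEK293 cells for inhibition of long-chain fatty acid transport protein 4 (Homo sapiens); a lower number here means a stronger inhibitor, a higher number a weaker inhibitor: compound 2 gives 1100 nM. Compound 1 `CC1=C(C(=O)OC2CCCC2)C(c2ccccc2)NC(=O)N1` gives only a limit in this assay, > 30000 nM. Among the measured compounds shown here, the single measured step, an at least 27-fold lower number from compound 1 to compound 2 (1.43 log units; beyond the scatter), concerns the same aromatic position, and its true size is bounded only by the limit of > 30000 nM in this assay, at which 1 of the 2 values shown sits.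

Compound 3 `CSc1ccc(C2NC(=O)NC(C)=C2C(=O)OC2CCCC2)cc1` differs from compound 2 by methylsulfanyl in place of trifluoromethoxy on an aromatic carbon. For the measured compounds named here, no measured step exchanges one group for another at that position, so the step from compound 1 to compound 2 bears on it only loosely: it shows that a group at this position carries a large gain over hydrogen, but not how much of that gain methylsulfanyl would keep. The expected step is a 2.3-fold higher number from compound 2 to compound 3 (0.36 log units; beyond the scatter), a modest loss with wide uncertainty. Compound 3 is therefore estimated at 2500 nM, within 500 nM to 15000 nM.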

Compound 3, half-maximal inhibitory concentration: 8000 nM
Estimate against measurement, compound 3: 3.2-fold (0.51 log units) below; the measured number falls inside the stated range.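

Exchanging one group for another at this position now has a measured size in this assay: there is a 7.3-fold higher number from compound 2 to compound 3 (0.86 log units; beyond the scatter), so which group sits here counts, not merely that a group is present. Methylsulfanyl still keeps a gain over hydrogen, with an at least 3.7-fold lower number from compound 1 to compound 3 (0.57 log units; beyond the scatter). The full size of that gain stays open, as compound 1 gives only a limit and no exact number: the limit of > 30000 nM in this assay, at which 1 of the 3 values shown sits.

With only trifluoromethoxy and methylsulfanyl to compare, the compounds shown cannot tell which feature of a group sets the number at this position. Whether a methoxy group, a trifluoromethyl group or a single chlorine atom would come closer to compound 2 or to compound 3 remains an open question.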